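This account rests on a few compounds, and the source may have more. Where it says the series, first, only, none or still open, it means among the compounds named here.

Of the compounds shown here, two carrying the same selenocyanate-bearing core have been measured. Compound 1 `CCCCCCOC(=O)Nc1ccc([Se]C#N)cc1`, in a functional assay on PC-3 cells (Homo sapiens) for cytotoxicity, read by MTT assay, with a stated time of 72 h (on this read-out lower numbers stand for stronger inhibition of growth and higher numbers for weaker inhibition of growth), gives 44600 nM. Compound 2 `N#C[Se]c1ccc(NC(=O)OCc2ccc([N+](=O)[O-])cc2)cc1` gives 36500 nM in this assay , the lower of the two numbers, though its gap to compound 1 lies within the usual scatter, so no order between the two can be claimed.

Compound 3 `N#C[Se]c1ccc(NC(=O)OCc2ccccc2)cc1` has not yet been measured. It differs from compound 2 in one place: hydrogen in place of nitro on an aromatic carbon. For the measured compounds named here, no comparable step between measured compounds is available, so the size of its effect cannot be read from the data. Given that compound 1 and compound 2 both sit in the same weak range, the expectation is that this change moves the number little, if at all, beyond the scatter, in either direction. Compound 3 is therefore estimated at 40000 nM, with a range from 15000 nM to 100000 nM. That estimate means a step of a 1.1-fold higher number from compound 2 to compound 3 (0.04 log units; within the scatter) that is expected to stay within the scatter.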

Compound 3, concentration for total growth inhibition: 27800 nM
Estimate against measurement, compound 3: 1.4-fold (0.16 log units) above; measured number inside the range.
By their numbers in this assay, from the lowest: compounds 3, 2 and 1 (each within the scatter of the next).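

With hydrogen in place of nitro on an aromatic carbon, para to a large group, this assay gives a 1.3-fold lower number from compound 2 to compound 3 (0.12 log units; within the scatter), so at this position the nitro group shows no effect that can be separated from the scatter. Phenyl in place of pentyl on a saturated chain carbon bound to an oxygen next to a carbonyl group gives a 1.6-fold lower number from compound 1 to compound 3 (0.21 log units; within the scatter), so this exchange also stays within the scatter, and neither change yet marks a part of these compounds on which the number clearly depends. No measurement at hand offers an explanation for these steps.

From the compounds shown here alone, it remains open whether an amine or a carboxylic acid on that aromatic carbon, or a longer chain in place of the pentyl, would move the number beyond the scatter. Also open, going by these compounds, is what a thiocyanate in place of the selenocyanate would give.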